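The compounds below may be only part of what the source reports. "The series", "measured", "known", "first", "only" and "open" are said of these compounds alone.

Measured so far in a functional assay on HEK293 cells for agonist activity at D(4) dopamine receptor (Homo sapiens), read by FLIPR; a higher number here means a larger maximal response, a lower number a smaller maximal response:
compound 1 `O=C(CN1CCC(c2cccc[n+]2[O-])CC1)Nc1cccc(Cl)c1` gives 76%
compound 2 `C=Cc1cccc(C(=O)NCN2CCC(c3cccc[n+]3[O-])CC2)c1` gives 63%
compound 3 `O=C(CN1CCC(c2cccc[n+]2[O-])CC1)Nc1cccc(C(F)(F)F)c1` gives 75%

Compound 2 stands lowest of the three in this assay: compound 3 sits above it by a gap beyond the scatter, and compound 1 sits above it by a slightly larger gap, also beyond the scatter. Compound 4 `Cc1cc(C(=O)NCN2CCC(c3cccc[n+]3[O-])CC2)ccc1Cl` differs from compound 2 as follows: 4-chloro-3-methylphenyl in place of 3-vinylphenyl on a carbonyl carbon. Within the data shown here, the only measured step that exchanges one aryl substituent for another, a number 1 percentage points lower from compound 1 to compound 3 (within the scatter), stayed within the scatter, so a swap of substituents on the aryl group is expected to move the maximal response little. Among the measured compounds shown here, no measured pair compares a vinyl-bearing aryl with a chloro- and methyl-bearing one, and the shared core of compound 2 is otherwise untouched. The step of a number 2 percentage points higher from compound 2 to compound 4 (within the scatter) is therefore expected to remain within the scatter. Compound 4 is estimated at 65%, with a range of 52% to 78%.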

Compound 4, largest response reached (reported as efficacy), in percent of the reference or control that the assay uses: 62%
Compound 4: middle estimate off by 3 percentage points, on the high side, within the range that was stated.
By their numbers in this assay, from the lowest: compounds 4 and 2 (each within the scatter of the next); then compounds 3 and 1 (each within the scatter of the next).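

In this assay the exchange of 3-vinylphenyl for 4-chloro-3-methylphenyl on a carbonyl carbon leaves the maximal response flat (a number 1 percentage points lower from compound 2 to compound 4 (within the scatter)). Among these compounds, this is the first aryl exchange read on the core of compound 2, and it shows that this place accepts the loss of the double bond and the entry of chlorine and methyl without a change beyond the scatter. No evidence on hand accounts for this result.

Open, from the compounds shown here alone, is whether an amine or a carboxylic acid on the aryl group would move the maximal response at this place. Going by these compounds, a longer chain in place of the single carbon on the amide nitrogen also remains open.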